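From 2-chlorophenyl to 3-chlorophenyl: a change of place

The source may report more compounds than this note shows. Statements on the series, on what has been measured and on what is new or still open speak of the compounds shown alone.

Of the compounds shown here, two have so far been measured in a functional assay on Raji cells (Homo sapiens) for cytotoxicity, read by CCK-8 assay, with a stated time of 24 h; a higher number here means a weaker inhibitor, a lower number a stronger inhibitor. There, compound 1 (`C=CC(=O)N1C(=O)CC(c2ccc(OC)cc2)Sc2ccccc21`) gives 43300 nM and compound 2 (`C=CC(=O)N1C(=O)CC(c2ccccc2Cl)Sc2ccccc21`) gives 50400 nM, so these two numbers lie within the scatter of each other and set no order between them. Compound 3 (`C=CC(=O)N1C(=O)CC(c2cccc(Cl)c2)Sc2ccccc21`) has the same atoms as compound 2, joined differently: it carries 3-chlorophenyl in place of 2-chlorophenyl on a saturated ring carbon, next to the ring sulfur (3-chlorophenyl in place of 2-chlorophenyl on a saturated ring carbon). For the measured compounds named here, only one measured step bears on this change. That step, a 1.2-fold higher number from compound 1 to compound 2 (0.07 log units; within the scatter), is an exchange of 4-methoxyphenyl for 2-chlorophenyl on the same carbon, and it stays within the scatter. Going by the values given here, it is thin evidence, since no measured compound carries 3-chlorophenyl, and it offers no direction. A step beyond the scatter in this assay is therefore not expected. The expected change is a 1.1-fold lower number from compound 2 to compound 3 (0.02 log units; within the scatter), an estimate that stays within the scatter. For compound 3 the estimated value is 48000 nM, with an expected range from 28000 nM to 80000 nM.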

Compound 3, half-maximal inhibitory concentration: 47100 nM
Estimate against measurement, compound 3: 1.0-fold (0.01 log units) above; the measured number falls inside the stated range.
By their numbers in this assay, from the lowest: compounds 1, 3 and 2 (each within the scatter of the next).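

In this assay, this is the first change of place among these compounds: the same chlorine moves around the same phenyl ring, giving a 1.1-fold lower number from compound 2 to compound 3 (0.03 log units; within the scatter). On this saturated ring carbon, next to the ring sulfur, the 2-chlorophenyl and 3-chlorophenyl groups therefore set no order between the two compounds, and the exchange of 4-methoxyphenyl for 3-chlorophenyl, a 1.1-fold higher number from compound 1 to compound 3 (0.04 log units; within the scatter), adds a third comparison that also stays within the scatter, so none of the three groups shown stands apart from the others. No independent measurement is available to explain why these exchanges leave the number in the same region.

As far as these compounds go, the three compounds differ only in a substituted phenyl group on one carbon, so it remains open whether 4-chlorophenyl, a phenyl ring bearing a carboxylic acid or an amine, or a plain alkyl chain at this place would produce a step beyond the scatter. From the compounds shown here alone, it is also open how much the vinylcarbonyl group on the ring nitrogen matters to these numbers, a question that a compound carrying a saturated propanoyl group there could address.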